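The source may hold more compounds than are shown below. What is called first, only, known or untested is meant among the compounds shown, and "the series" means these compounds.

Of the compounds shown here, two have so far been tested in a functional assay on MCF7 cells (Homo sapiens) for inhibition, read by MTT assay, with a stated time of 48 h (on this read-out higher numbers stand for weaker inhibition and lower numbers for stronger inhibition), with a number to show for it. Compound 1 (`c1ccc(C(c2c[nH]c3ccccc23)c2c[nH]c3ccccc23)cc1`) gives 22200 nM there, and compound 2 (`COc1ccc(C(c2c[nH]c3ccc(Br)cc23)c2c[nH]c3ccc(Br)cc23)cc1OC`) gives 7800 nM there. Compound 2 therefore holds the lower of the two numbers, and the gap between them lies beyond the scatter of repeat measurements. The two compounds differ in more than one place, so that gap cannot be tied to any single group.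

Compound 3 (`Clc1ccc(C(c2c[nH]c3ccc(Br)cc23)c2c[nH]c3ccc(Br)cc23)cc1`) has not yet been measured. It differs from compound 2 in one place: 4-chlorophenyl in place of 3,4-dimethoxyphenyl on a saturated chain carbon bound to two aromatic carbons. Among the measured compounds shown here, no measured pair shows what this swap does, so the expectation is a loose one. Compound 3 keeps the rest of compound 2, which makes compound 2 at 7800 nM the natural starting point. The expected result in this assay is no step beyond the scatter, with an estimated 1.2-fold lower number from compound 2 to compound 3 (0.08 log units; within the scatter) as the size of the change. For compound 3 the estimate is 6500 nM as a middle value, with an expected range from 2500 nM to 17000 nM in this read-out.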

Compound 3, half-maximal inhibitory concentration: 3500 nM
Compound 3: the middle estimate sits 1.9-fold (0.27 log units) above what was measured; low and high end bracket the measured number.
By their numbers in this assay, from the lowest: compound 3; then compound 2; then compound 1.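

Among the compounds shown here, this is the first comparison in this assay in which only one place changes: on a saturated chain carbon bound to two aromatic carbons, 4-chlorophenyl in place of 3,4-dimethoxyphenyl gives a 2.2-fold lower number from compound 2 to compound 3 (0.35 log units; beyond the scatter), a modest step but one that lies beyond the scatter of repeat measurements. The group at this place can therefore shift the number, and with the rest of the molecule held fixed, the 4-chlorophenyl version gives the stronger inhibition of this pair. The swap alters several features at once, as the entering group has fewer heavy atoms, carries chlorine rather than oxygen and has no hydrogen-bond acceptors, and no measurement at hand explains why the number falls.

Still open, as far as these compounds go, is whether the step comes from the chlorine arriving, the methoxy groups leaving or both, which a plain phenyl or a 4-methoxyphenyl at this place, with the rest of compound 3 kept, could help to separate. Also open, from the compounds shown here alone, is how a 4-fluorophenyl, or a phenyl bearing an amine or a carboxylic acid, would behave here.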